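Thiophene attachment shift in a weakly cytotoxic series

The compounds below may be only part of what the source reports. "The series", "measured", "known", "first", "only" and "open" are said of these compounds alone.

Going by the values given here, compound 2 `Clc1ccc(-c2cc(-c3cccs3)nc(-c3cccs3)c2)o1` gives in a functional assay on DU-145 cells (Homo sapiens) for cytotoxicity, with a stated time of 3 days (on this read-out lower numbers stand for stronger inhibition and higher numbers for weaker inhibition), a value of 88100 nM; this is the only number in the set. Compound 1 `c1csc(-c2cc(-c3ccoc3)cc(-c3cccs3)n2)c1` in this assay gives > 100000 nM, which is a limit of the assay and not a number (the limit of > 100000 nM in this assay, at which 1 of the 2 values shown sits). Among the compounds with values here, the single measured step, an at least 1.1-fold lower number from compound 1 to compound 2 (0.05 log units; that floor lies within the scatter), replaces furan-3-yl by 5-chlorofuran-2-yl on an aromatic carbon, and its floor lies within the scatter, so it shows no clear movement.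

Compound 3 `Clc1ccc(-c2cc(-c3ccsc3)nc(-c3cccs3)c2)o1` differs from compound 2 by thiophen-3-yl in place of thiophen-2-yl on an aromatic carbon. Within the data shown here, no measured step touches a thiophene attachment swap; the one step on record concerns the furan ring and is itself within the scatter. There is thus no basis for expecting a step beyond the scatter in this assay in either direction. The expected value for compound 3 in this assay is 90000 nM, with a range from 30000 nM to 300000 nM. That corresponds to an expected step of a 1.0-fold higher number from compound 2 to compound 3 (0.01 log units; within the scatter), within the scatter, and a real chance that only a limit is returned.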

Compound 3, half-maximal inhibitory concentration: > 100000 nM
Compound 3 was reported as a limit (the forecaster's own chance of this, stated with the estimate: 40%); middle value at least 1.1-fold (0.04 log units) from the limit.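

In this assay, the earlier step concerned the furan ring, whereas this one changes the group next to the ring nitrogen, meta to the 5-chlorofuran-2-yl group. There, thiophen-3-yl in place of thiophen-2-yl gives an at least 1.1-fold higher number from compound 2 to compound 3 (0.05 log units; that floor lies within the scatter), so the change in attachment shows no clear movement. Compound 3 gives > 100000 nM, which is a limit of the assay and not a number, and the series now sits largely at the edge of the read-out, so that a step at this place can be read only as a floor: the limit of > 100000 nM in this assay, at which 2 of the 3 values shown sit.

How far compound 3 actually lies from compound 2 remains unresolved, as does whether the thiophene attachment matters at all in a compound whose value lies well inside the range of the assay. Also open, on these data alone, is whether a different kind of group at this place, such as an amine or a carboxylic acid in place of the thiophene, would move the value beyond the scatter.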